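Series notes: from compound 3 to compound 4

The source may hold more compounds than are shown below. What is called first, only, known or untested is meant among the compounds shown, and "the series" means these compounds.

Compound 1 `COc1cc(C(=O)N/N=C/c2ccc(C(F)(F)F)cc2)cc(OC)c1OC`: 61.6%
Compound 2 `COc1cc(C(=O)N/N=C/c2ccc(Cl)c([N+](=O)[O-])c2)cc(OC)c1OC`: 42.3%
Compound 3 `COc1cc(C(=O)N/N=C/c2ccc(Cl)c(Cl)c2)cc(OC)c1OC`: 31.6%

In a functional assay on PC-3 cells (Homo sapiens) for antiproliferative activity, read by MTT assay, tested at 5 uM (a lower number here means a weaker effect, a higher number a stronger effect of the compound at the concentration tested), compound 3 gives 31.6%, the lowest of the three values; compound 2 gives 42.3% and compound 1 gives 61.6%, both beyond the scatter above it. Among the measured compounds shown here, the single measured step, a number 10.7 percentage points lower from compound 2 to compound 3 (beyond the scatter), alters one group on the aryl ring that compound 4 replaces entirely, so it bears only loosely on the present change. Compound 4 `COc1cc(C(=O)N/N=C/c2ccc(F)cc2)cc(OC)c1OC` differs from compound 3 by 4-fluorophenyl in place of 3,4-dichlorophenyl on a carbon with a double bond to nitrogen. For the measured compounds named here, no measured pair isolates this exchange; compound 1, whose ring carries a trifluoromethyl group alone, gives 61.6%. Compound 4 is therefore expected at 45% (range 25% to 65%). The expected step is a number 13.4 percentage points higher from compound 3 to compound 4 (beyond the scatter), upward but uncertain.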

Compound 4, a percentage reported as inhibition, at one concentration (the size of the read-out at that concentration, not a potency): 82.8%
For compound 4 the middle estimate is 37.8 percentage points below the measured one, outside the stated range (above it).
By their numbers in this assay, from the lowest: compound 3; then compound 2; then compound 1; then compound 4.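

In this assay, the aryl group on the carbon with a double bond to nitrogen has a large bearing on the read-out: 4-fluorophenyl in place of 3,4-dichlorophenyl gives a number 51.2 percentage points higher from compound 3 to compound 4 (beyond the scatter). Fluoro in place of trifluoromethyl on an aromatic carbon also raises the read-out, with a number 21.2 percentage points higher from compound 1 to compound 4 (beyond the scatter), so both single-place changes ending at compound 4 point upward. No available data explain either step.

As far as these compounds go, whether a single chloro would behave like the fluoro of compound 4 remains open. So does the effect of an amine or a carboxylic acid on that aromatic carbon.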